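The source may report more compounds than this note shows. Statements on the series, on what has been measured and on what is new or still open speak of the compounds shown alone.

Working notes on the series. Compound 1 `O=C(CSC(=S)N[C@H]1CCOC1=O)Nc1ccc(Cl)cc1` carries a chloro on the aromatic carbon. In a functional assay on SMMC-7721 cells (Homo sapiens) for cytotoxicity, read by MTT assay, with a stated time of 72 h (on this read-out lower numbers stand for stronger inhibition and higher numbers for weaker inhibition), compound 1 gives > 128000 nM, which is a limit of the assay and not a number. Compound 2 `O=C(CSC(=S)N[C@H]1CCOC1=O)Nc1ccc(O)cc1` has hydroxy in that place; in this assay compound 2 gives > 128000 nM, again a limit. Among the compounds with values here, compound 3 `CCOC(=O)c1ccc(NC(=O)CSC(=S)N[C@H]2CCOC2=O)cc1` carries ethoxycarbonyl there, and in this assay compound 3 gives 64900 nM, the only number the series has so far. The step of an at least 1.9-fold lower number from compound 1 to compound 3 (0.29 log units; that floor lies within the scatter) and the step of an at least 1.9-fold lower number from compound 2 to compound 3 (0.29 log units; that floor lies within the scatter) are both floors set by the limit of > 128000 nM in this assay, at which 2 of the 3 values shown sit, and the step that the two limits leave unreadable from compound 1 to compound 2 cannot be read at all.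

Compound 4 `O=C(CSC(=S)N[C@H]1CCOC1=O)Nc1ccc(C(=O)/C=C/c2ccccc2)cc1` differs from compound 3 by 2-phenylethenyl in place of ethoxy on a carbonyl carbon. Within the data shown here, no measured step touches that carbonyl carbon; the three steps seen all sit at the aromatic carbon, and they show only that ethoxycarbonyl yields a number where chloro and hydroxy yield limits. The expectation for compound 4 in this assay is therefore anchored on compound 3 alone, with a step of a 1.6-fold lower number from compound 3 to compound 4 (0.21 log units; within the scatter) not claimed beyond the scatter in either direction. Compound 4 is estimated at 40000 nM, between 8000 nM and 128000 nM.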

Compound 4, half-maximal inhibitory concentration: > 128000 nM
Compound 4: no number, only a limit (the forecaster's own chance of this, stated with the estimate: 25%); at least 3.2-fold (0.50 log units) between middle value and limit.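

In this assay the carbonyl carbon now has a measured step of its own: 2-phenylethenyl in place of ethoxy gives an at least 1.9-fold higher number from compound 3 to compound 4 (0.29 log units; that floor lies within the scatter). Within the data shown here, a carbonyl on the aromatic carbon is therefore not enough to yield a number, for (2-phenylethenyl)carbonyl in compound 4 ends at a limit as chloro in compound 1 and hydroxy in compound 2 do, and ethoxycarbonyl in compound 3 remains the only group of the four with a number. The steps from compound 1 and from compound 2 to compound 4 join two limits and cannot be read, and the series stays bounded by a single ceiling: the limit of > 128000 nM in this assay, at which 3 of the 4 values shown sit.

The size of the step to compound 4 remains unknown beyond its floor, and the compounds shown do not separate the aromatic ring of 2-phenylethenyl from its double bond. Also open, going by these compounds, is whether methyl on the same carbonyl carbon, or a carboxylic acid in place of ethoxycarbonyl on the aromatic carbon, would give a number in this assay or another limit.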